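Ethyl Sulfonamide Analog of a Fluoro Benzamide: Cytotoxicity Outlook

A few compounds are considered here, and "the series" means these few. Any claim that something is new, unique, unknown or untested is made for them only; others in the source may bear on it.

compound 1 `CCS(=O)(=O)Nc1ccc(NC(=O)c2cccc(C(F)(F)F)c2)cc1C`: 210000 nM
compound 2 `CCS(=O)(=O)Nc1ccc(NC(=O)c2cccc(C(F)(F)F)c2)cc1Cl`: 159000 nM
compound 3 `CS(=O)(=O)Nc1ccc(NC(=O)c2cccc(C(F)(F)F)c2)cc1F`: > 250000 nM

In an ADME assay on HEK293 cells (Homo sapiens) for cytotoxicity, read by MTT assay, with a stated time of 48 h (a lower number here means a stronger inhibitor, a higher number a weaker inhibitor), compound 1 gives 210000 nM. Compound 2 gives 159000 nM, and the step of a 1.3-fold lower number from compound 1 to compound 2 (0.12 log units; within the scatter) is within the scatter. For compound 3 the assay reports only a limit, > 250000 nM, as recorded in the limit of > 250000 nM in this assay, at which 1 of the 3 values shown sits. Compound 3 therefore stands at the limit of this assay, where the other two compounds give numbers.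

Compound 4 `CCS(=O)(=O)Nc1ccc(NC(=O)c2cccc(C(F)(F)F)c2)cc1F` differs from compound 3 by methyl in place of hydrogen on a saturated chain carbon bound to a sulfonyl sulfur. Going by the values given here, no measured step touches this sulfonyl chain, and the only measured step, a 1.3-fold lower number from compound 1 to compound 2 (0.12 log units; within the scatter), was within the scatter. Compound 4 is consequently expected to show no step beyond the scatter, an at least 1.0-fold lower number from compound 3 to compound 4 (0.03 log units; that floor lies within the scatter), with an estimated value of 230000 nM and a range from 120000 nM to 500000 nM.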

Compound 4, half-maximal inhibitory concentration: 94800 nM
Estimate against measurement, compound 4: 2.4-fold (0.38 log units) above; the measured number lies below the stated range.
By their numbers in this assay, from the lowest: compounds 4, 2 and 1 (each within the scatter of the next, the first and the last beyond it). At a limit, above all of these: compound 3.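

In this assay, going by these compounds alone, methyl in place of hydrogen on the saturated chain carbon bound to a sulfonyl sulfur gives an at least 2.6-fold lower number from compound 3 to compound 4 (0.42 log units; beyond the scatter) and so shifts the number at a place no earlier step touched. With the ethylsulfonyl chain kept, fluoro on the aromatic carbon gives a 2.2-fold lower number from compound 1 to compound 4 (0.35 log units; beyond the scatter) and also a 1.7-fold lower number from compound 2 to compound 4 (0.22 log units; within the scatter) for the two other groups there. Compound 3 holds only a limit, so the first step has a floor and no exact size: the limit of > 250000 nM in this assay, at which 1 of the 4 values shown sits.

Going by these compounds, whether a longer chain, such as propyl, on the sulfonyl sulfur continues this step stays open. So does whether an amine on the aromatic carbon departs from these values.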